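The source may report more compounds than this note shows. Statements on the series, on what has been measured and on what is new or still open speak of the compounds shown alone.

Compound 1 `Cc1cc(C)cc(S(=O)(=O)c2c(C(=O)N[C@@H]3CCNC3)[nH]c3ccc(Cl)cc23)c1` gives 37300 nM in an ADME assay on MT4 cells (Homo sapiens) for cytotoxicity, read by MTT assay, with a stated time of 5 days (on this read-out lower numbers stand for higher toxicity in this test and higher numbers for lower toxicity in this test), and compound 2 `Cc1cc(C)cc(S(=O)(=O)c2c(C(=O)N[C@H]3CCN(CC(N)=O)C3)[nH]c3ccc(Cl)cc23)c1` gives 28100 nM in this assay; the two sit within the scatter of each other, as a 1.3-fold lower number from compound 1 to compound 2 (0.12 log units; within the scatter) shows. Compound 3 `CCCS(=O)(=O)NC(=O)c1[nH]c2ccc(Cl)cc2c1S(=O)(=O)c1cc(C)cc(C)c1` carries propylsulfonyl in place of 1-(carbamoylmethyl)pyrrolidin-3-yl on an amide-type nitrogen. Among the measured compounds shown here, only that one step from compound 1 to compound 2 bears on this change, and it stayed within the scatter, so compound 3 is expected to show no step beyond the scatter, with a 1.1-fold higher number from compound 2 to compound 3 (0.03 log units; within the scatter) as the estimated size. Compound 3 is thus estimated at 30000 nM, within a range of 10000 nM to 90000 nM.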

Compound 3, half-maximal cytotoxic concentration: 146000 nM
Beside the measured number, compound 3's estimate is 4.9-fold (0.69 log units) below it; measured number above the stated range.
By their numbers in this assay, from the lowest: compounds 2 and 1 (each within the scatter of the next); then compound 3.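

At this amide-type nitrogen the group does move the number in this assay: propylsulfonyl in place of 1-(carbamoylmethyl)pyrrolidin-3-yl gives a 5.2-fold higher number from compound 2 to compound 3 (0.72 log units; beyond the scatter) and propylsulfonyl in place of pyrrolidin-3-yl gives a 3.9-fold higher number from compound 1 to compound 3 (0.59 log units; beyond the scatter) and both steps lie beyond the scatter. Among the compounds shown here, the earlier change at this place stayed within it, so this is the first sign of lower toxicity in this test from a change here. Nothing measured here accounts for the shift. The compounds shown leave open whether the higher number goes with the sulfonyl or with the propyl chain. A plain propyl group or a longer alkylsulfonyl chain on this nitrogen would separate the two.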